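The source may hold more compounds than are shown below. What is called first, only, known or untested is meant among the compounds shown, and "the series" means these compounds.

Working notes on the series. Compound 1 `CCS(=O)(=O)NC(=O)c1ccc(Nc2nc(NC3(c4ccc(Cl)cc4)CC3)nc(OCC(F)(F)F)n2)cc1` gives 100% in an ADME assay on microsomes from liver (Homo sapiens) for metabolic stability, with a stated time of 10 min; a higher number here means that more of the compound is left, a lower number that less of the compound is left. Compound 2 `O=C(NS(=O)(=O)CCNC(=O)C1CC1)c1ccc(Nc2nc(NC3(c4ccc(Cl)cc4)CC3)nc(OCC(F)(F)F)n2)cc1` gives 90%; compound 3 `CC(C)NC(=O)NCCS(=O)(=O)NC(=O)c1ccc(Nc2nc(NC3(c4ccc(Cl)cc4)CC3)nc(OCC(F)(F)F)n2)cc1` gives 100%. Compound 3 thus stands level with compound 1 at the digits shown, the two together the highest of the three numbers, with compound 2 the furthest off and still within the scatter. Compound 4 `O=C(NS(=O)(=O)CCNCc1ccccc1)c1ccc(Nc2nc(NC3(c4ccc(Cl)cc4)CC3)nc(OCC(F)(F)F)n2)cc1` differs from compound 3 by benzyl in place of isopropylcarbamoyl on an amine nitrogen. The measured steps of a number 10 percentage points lower from compound 1 to compound 2 (within the scatter), no change at the digits printed from compound 1 to compound 3 (within the scatter) and a number 10 percentage points higher from compound 2 to compound 3 (within the scatter) all stayed within the scatter, but none of them covers a benzyl entering on this amine nitrogen, so the expected step of a number 20 percentage points lower from compound 3 to compound 4 (beyond the scatter) is set downward with a wide range. For compound 4 the estimate is 80%, between 50% and 100%.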

Compound 4, percent of the compound remaining: 99%
Estimate against measurement, compound 4: 19 percentage points below, and the stated range covers the measured number.
By their numbers in this assay, from the lowest: compounds 2, 4, 1 and 3 (each within the scatter of the next).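

In this assay the carbonyl on this amine nitrogen is not needed to hold the number: benzyl in place of isopropylcarbamoyl gives a number 1 percentage points lower from compound 3 to compound 4 (within the scatter) and benzyl in place of cyclopropylcarbonyl gives a number 9 percentage points higher from compound 2 to compound 4 (within the scatter) as well. Benzylamino on the saturated chain carbon gives a number 1 percentage points lower from compound 1 to compound 4 (within the scatter) and so brings an aromatic ring to this place with no step beyond the scatter. No supporting measurement bears on this result.

On these data alone, a free amine, a carboxylic acid on the benzyl ring or a longer chain at this nitrogen remains open.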